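Lengthening the ring substituent on the way to compound 4

A few compounds are considered here, and "the series" means these few. Any claim that something is new, unique, unknown or untested is made for them only; others in the source may bear on it.

Compound 3 `Cc1cc(C)cc(-c2c(O)nc3cc(Cl)c([N+](=O)[O-])cc3c2OCCC2NCCCC2C)c1` gives 45 nM in an assay on isolated protein for inhibition of Gonadotropin-releasing hormone receptor (Rattus norvegicus) (a lower number here means a stronger inhibitor, a higher number a weaker inhibitor), the second highest of the three numbers at hand. Compound 1 `Cc1cc(C)cc(-c2c(O)nc3cc(Cl)c([N+](=O)[O-])cc3c2OCC[C@@H]2CCC[C@H](C)N2)c1` gives 15 nM, and compound 2 `Cc1cc(C)cc(-c2c(O)nc3cc(Cl)c([N+](=O)[O-])cc3c2OCCC2CCC(C)CN2)c1` gives 63 nM. Compound 4 `CC[C@H]1CCC[C@@H](CCOc2c(-c3cc(C)cc(C)c3)c(O)nc3cc(Cl)c([N+](=O)[O-])cc23)N1` differs from compound 3 by 6-ethylpiperidin-2-yl in place of 3-methylpiperidin-2-yl on a saturated chain carbon, two bonds along the chain from an oxygen on an aromatic ring. Within the data shown here, two measured steps bear on this change: a 3.0-fold higher number from compound 1 to compound 3 (0.48 log units; beyond the scatter) and a 4.2-fold higher number from compound 1 to compound 2 (0.62 log units; beyond the scatter), both modest rises when the methyl left the arrangement of 6-methylpiperidin-2-yl. Compound 4 restores that arrangement with an ethyl in place of the methyl, and a modest step back toward compound 1 at 15 nM is expected, estimated as a 2.3-fold lower number from compound 3 to compound 4 (0.35 log units; beyond the scatter). Compound 4 is therefore estimated at 20 nM, within a range from 7 nM to 60 nM.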

Compound 4, half-maximal inhibitory concentration: 18 nM
Compound 4: middle estimate off by 1.1-fold (0.05 log units), on the high side; measured number inside the range.
By their numbers in this assay, from the lowest: compounds 1 and 4 (each within the scatter of the next); then compounds 3 and 2 (each within the scatter of the next).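

Replacing the methyl of 6-methylpiperidin-2-yl with an ethyl leaves the number unresolved from that of the parent, with a 1.2-fold higher number from compound 1 to compound 4 (0.08 log units; within the scatter) in this assay, so the longer group is tolerated there. The ethyl compound also keeps the gap to the other ring arrangements, with a 2.5-fold lower number from compound 3 to compound 4 (0.40 log units; beyond the scatter) and a 3.5-fold lower number from compound 2 to compound 4 (0.54 log units; beyond the scatter), so this advantage is not limited to the methyl. Nothing available explains these differences.

From the compounds shown here alone, whether a propyl or cyclopropyl group would do as well remains open. So does how much of the gap depends on the two defined stereocentres of 6-ethylpiperidin-2-yl, which 3-methylpiperidin-2-yl lacks.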